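Methoxy and hydroxy variants of an imine series

The source may report more compounds than this note shows. Statements on the series, on what has been measured and on what is new or still open speak of the compounds shown alone.

Measured so far:
Compound 1, `COc1ccc(/C=N/c2c(C)n(C)n(-c3ccccc3)c2=O)cc1OC`: in a functional assay on HT-29 cells (Homo sapiens) for cytotoxicity, read by MTT assay, with a stated time of 72 h (a higher number here means a weaker inhibitor, a lower number a stronger inhibitor), compound 1 gives 603000000 nM.
Compound 2, `COc1cc(/C=N/c2c(C)n(C)n(-c3ccccc3)c2=O)ccc1O`: in this assay compound 2 gives 537000000 nM.
Compound 3, `Cc1c(/N=C/c2ccc(O)cc2)c(=O)n(-c2ccccc2)n1C`: in this assay compound 3 gives 389000000 nM.

All three numbers sit within the scatter of one another. The step from compound 1 to compound 2, hydrogen in place of methyl on an oxygen on an aromatic ring, gives a 1.1-fold lower number from compound 1 to compound 2 (0.05 log units; within the scatter). The step from compound 3 to compound 2 is methoxy in place of hydrogen on an aromatic carbon and gives a 1.4-fold higher number from compound 3 to compound 2 (0.14 log units; within the scatter). The difference between the core of compound 1 and the core of compound 3 is not broken down here.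

Compound 4, `COc1cc(/C=N/c2c(C)n(C)n(-c3ccccc3)c2=O)cc(OC)c1OC`, is not yet measured. It differs from compound 1 by methoxy in place of hydrogen on an aromatic carbon. This is the same kind of change as that from compound 3 to compound 2, but not the same: the earlier methoxy entered ortho to a hydroxy group (1 heavy atom), whereas here it enters ortho to a methoxy group (2 heavy atoms) and meta to a methoxy group (2 heavy atoms). The change from compound 3 to compound 2 stayed within the scatter, and nothing among the three measured compounds sets them apart from one another, so the step to compound 4 is expected to stay within the scatter as well, estimated at a 1.0-fold lower number from compound 1 to compound 4 (0.00 log units; within the scatter) because a 1.4-fold higher number from compound 3 to compound 2 (0.14 log units; within the scatter). Compound 4 is therefore expected to give 600000000 nM in this assay, with a range estimated from 300000000 nM to 1200000000 nM.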

Compound 4, half-maximal inhibitory concentration: 275000000 nM
For compound 4 the middle estimate is 2.2-fold (0.34 log units) above the measured one, and the stated range ends above it.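

In this assay, methoxy in place of hydrogen on an aromatic carbon gives a 2.2-fold lower number from compound 1 to compound 4 (0.34 log units; beyond the scatter), a modest step, and the same change does not read the same way on the two cores: the same change on two cores in this assay, a 1.4-fold higher number (0.14 log units; within the scatter) from compound 3 to compound 2 and a 2.2-fold lower number (0.34 log units; beyond the scatter) from compound 1 to compound 4, 3.0-fold (0.48 log units) apart, beyond the scatter of two such steps. The size of this step therefore cannot be carried from one core to the other in this series, and a small step on one core gives no safe estimate for the same change on the other. This does not show whether the difference between the cores or the surrounding groups accounts for the gap, since the methoxy of compound 4 enters ortho to a methoxy group and meta to a methoxy group, whereas the earlier one entered ortho to a hydroxy group, and with one pair on each side no general rule for the series follows.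

From the compounds shown here alone, how an amine, a carboxylic acid or a chlorine atom in place of hydrogen on this same aromatic ring would read in this assay remains open. Also open, going by these compounds, is whether a longer chain in place of the methyl groups on the shared core would leave the step from methoxy unchanged.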